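Taking the methoxy off the core of compound 3

The compounds below may be only part of what the source reports. "The series", "measured", "known", "first", "only" and "open" are said of these compounds alone.

Measured in a functional assay on LNCaP C4-2B cells (Homo sapiens) for antiproliferative activity, read by luminescence, with a stated time of 96 h; on this read-out lower numbers stand for stronger inhibition and higher numbers for weaker inhibition:
compound 1 `CC1(C)Oc2cc(NS(=O)(=O)c3ccc(F)cc3Cl)ccc2NC1=O`: 7160 nM
compound 2 `CC1(C)Oc2cc(NS(=O)(=O)c3ccccc3)ccc2NC1=O`: 13300 nM
compound 3 `COc1cc2c(cc1NS(=O)(=O)c1cc(Br)ccc1OC)OC(C)(C)C(=O)N2`: 3230 nM

Compound 3 stands lowest of the three, at 3230 nM. Compound 4 `COc1ccc(Br)cc1S(=O)(=O)Nc1ccc2c(c1)OC(C)(C)C(=O)N2` keeps the same group on its sulfonyl sulfur but has hydrogen in place of methoxy on an aromatic carbon. Among the compounds with values here, the only measured step, a 1.9-fold higher number from compound 1 to compound 2 (0.27 log units; within the scatter), changes the group on the sulfonyl sulfur instead, and no measured step tests the new change directly. Still, compound 1 at 7160 nM and compound 2 at 13300 nM also lack this methoxy, and both stand above compound 3 in this assay, though their sulfonyl groups differ too. A moderate rise is therefore expected, a 1.9-fold higher number from compound 3 to compound 4 (0.27 log units; within the scatter). For compound 4 the estimated value is 6000 nM, with an expected range of 2200 nM to 15000 nM.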

Compound 4, half-maximal inhibitory concentration: 6560 nM
Compound 4: middle estimate off by 1.1-fold (0.04 log units), on the low side; measured number inside the range.
By their numbers in this assay, from the lowest: compound 3; then compounds 4, 1 and 2 (each within the scatter of the next, the first and the last beyond it).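

Within the data shown here, putting hydrogen in place of methoxy on the core gives a 2.0-fold higher number from compound 3 to compound 4 (0.31 log units; beyond the scatter) in this assay and is the first reading of this position with the sulfonyl group held fixed. Among these compounds, the step is modest, yet it ties the lower number to the methoxy itself, which the earlier compounds could not do while their sulfonyl groups differed too. Nothing at hand explains the step. From the compounds shown here alone, whether an ethoxy, a fluorine or an amine at this position would give a lower or higher number stays open. So does whether the step would hold with phenyl on the sulfonyl sulfur.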